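The source may hold more compounds than are shown below. What is called first, only, known or untested is meant among the compounds shown, and "the series" means these compounds.

Compound 1, with structure `Oc1c(C(Nc2ccccn2)c2ccccc2F)ccc2cccnc12`, is measured in an assay for inhibition of protein disulfide-isomerase (Homo sapiens), with a stated time of 1 h (on this read-out lower numbers stand for stronger inhibition and higher numbers for weaker inhibition), and gives 470 nM. Of the two plain numbers recorded, compound 1 has the lowest; the nearest is compound 2, whose structure is `Cc1ccnc(NC(c2ccccc2F)c2ccc3cccnc3c2O)c1` and whose result in this assay is 880 nM. The step of a 1.9-fold higher number from compound 1 to compound 2 (0.27 log units; within the scatter) lies within the scatter, so the two cannot be ordered. Compound 3, with structure `Oc1ccc2ncccc2c1C(c1ccc(F)cc1)N1CCCCC1`, reaches only a limit of the assay, > 30000 nM, and no number; that is the limit of > 30000 nM in this assay, at which 1 of the 3 values shown sits.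

Compound 4, with structure `Oc1c(C(Nc2ccccn2)c2ccc(Cl)cc2)ccc2cccnc12`, has not yet been measured. Its difference from compound 1 is 4-chlorophenyl in place of 2-fluorophenyl on a saturated chain carbon bound to an aromatic carbon and a nitrogen on an aromatic ring. Among the measured compounds shown here, none of the measured steps touches this position: the single step recorded changes a group on an aromatic carbon elsewhere in the core, and compound 3 differs from compound 1 in more than one place. An expectation can therefore only rest loosely on compound 1, whose value of 470 nM anchors it, and some weakening beyond the scatter is estimated as the step of a 2.3-fold higher number from compound 1 to compound 4 (0.37 log units; beyond the scatter). For compound 4, a result of 1100 nM is expected, with a range from 250 nM to 5000 nM.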

Compound 4, half-maximal inhibitory concentration: 170 nM
For compound 4 the middle estimate is 6.5-fold (0.81 log units) above the measured one; measured number below the stated range.
By their numbers in this assay, from the lowest: compound 4; then compounds 1 and 2 (each within the scatter of the next). At a limit, above all of these: compound 3.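

Replacing 2-fluorophenyl with 4-chlorophenyl gives a 2.8-fold lower number from compound 1 to compound 4 (0.44 log units; beyond the scatter), so in this assay this position responds to a change in the aromatic ring it carries, and here the change goes towards stronger inhibition. The swap alters two things at once, the halogen and where it sits on the ring, so this single step cannot show which of them matters. Nothing measured here accounts for the shift.

Open, as far as these compounds go, is how 4-fluorophenyl or 2-chlorophenyl would compare, as either compound would separate the effect of the halogen from that of its place on the ring. Also open, from the compounds shown here alone, is whether this position needs a halogen or an aromatic ring at all, which an unsubstituted phenyl or a cyclohexyl group would test.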